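Testing a Hydroxymethylpiperidine Group in a Cholesterol Transporter Binding Assay

The compounds below may be only part of what the source reports. "The series", "measured", "known", "first", "only" and "open" are said of these compounds alone.

Compound 1 `CC1(C)CC(OC(=O)CN2CN(c3ccccc3)C3(CCN(C(=O)c4ccc(C(C)(C)C)cc4)CC3)C2=O)CC(C)(C)N1`: 1300 nM
Compound 2 `O=C(CN1CN(c2ccccc2)C2(CCN(C(=O)c3ccc(C4CCCCC4)cc3)CC2)C1=O)N1CCC(CO)CC1`: 1100 nM

In a binding assay on HEK293 cells for displacement of a labelled ligand from NPC1-like intracellular cholesterol transporter 1 (Homo sapiens) (a lower number here means a stronger inhibitor, a higher number a weaker inhibitor), compound 1 gives 1300 nM, and compound 2 gives 1100 nM. These two numbers lie within the scatter of each other, so neither compound can be set apart from the other. Compound 3 `CC(C)(C)c1ccc(C(=O)N2CCC3(CC2)C(=O)N(CC(=O)N2CCCCC2CO)CN3c2ccccc2)cc1` has not yet been measured. It differs from compound 1 in one place: 2-(hydroxymethyl)piperidin-1-yl in place of (2,2,6,6-tetramethylpiperidin-4-yl)oxy on a carbonyl carbon. Compound 2 carries a related group in that place and gives 1100 nM in this assay, which supports a small expected step. The expected step is a 1.3-fold lower number from compound 1 to compound 3 (0.11 log units; within the scatter), not beyond the scatter. Compound 3 is estimated at 1000 nM, within 400 nM to 2500 nM.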

Compound 3, half-maximal inhibitory concentration: 11800 nM
Beside the measured number, compound 3's estimate is 12-fold (1.07 log units) below it, outside the stated range (above it).
By their numbers in this assay, from the lowest: compounds 2 and 1 (each within the scatter of the next); then compound 3.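

In this assay the group on this carbonyl carbon clearly matters: putting 2-(hydroxymethyl)piperidin-1-yl in place of (2,2,6,6-tetramethylpiperidin-4-yl)oxy gives a 9.1-fold higher number from compound 1 to compound 3 (0.96 log units; beyond the scatter) and so the two groups are not interchangeable on this core. Compound 2 also carries a hydroxymethyl-bearing piperidine in this place, but it differs from compound 3 in more than one place, so it cannot be read against this step. Nothing measured here explains the change.

Whether the hydroxymethyl or the rest of the new group accounts for the step stays open. A plain piperidin-1-yl on this carbonyl carbon would speak to that.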